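Ether chain variation on the shared core

A few compounds are considered here, and "the series" means these few. Any claim that something is new, unique, unknown or untested is made for them only; others in the source may bear on it.

Measured so far in an assay on cells with melanin-concentrating hormone receptor 1 (Homo sapiens) as the target, read by radioligand binding; on this read-out lower numbers stand for stronger inhibition and higher numbers for weaker inhibition:
compound 1 `Nc1ccc2cccc(OCCC(F)(F)F)c2n1` gives 722 nM
compound 2 `CCCCCOc1cccc2ccc(N)nc12` gives 580 nM
compound 3 `CC(C)Oc1cccc2ccc(N)nc12` gives 437 nM

Compound 3 has the lowest of the three numbers, yet every step to it lies within the scatter: a 1.3-fold lower number from compound 2 to compound 3 (0.12 log units; within the scatter) and a 1.7-fold lower number from compound 1 to compound 3 (0.22 log units; within the scatter). The remaining step, a 1.2-fold lower number from compound 1 to compound 2 (0.10 log units; within the scatter), is also within the scatter. Across these three ethers on the same oxygen the numbers do not separate from one another.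

Compound 4 `CCCOc1cccc2ccc(N)nc12` has not yet been measured. It differs from compound 3 by propyl in place of isopropyl on an oxygen on an aromatic ring. For the measured compounds named here, the steps that bear on this change are those that swap the chain on the same oxygen of the shared core: a 1.3-fold lower number from compound 2 to compound 3 (0.12 log units; within the scatter) and a 1.7-fold lower number from compound 1 to compound 3 (0.22 log units; within the scatter), both within the scatter, as is a 1.2-fold lower number from compound 1 to compound 2 (0.10 log units; within the scatter). Three different chains at that position left the number in one narrow band, so for a propyl chain no step beyond the scatter is expected in this assay in either direction; the expected step is a 1.1-fold higher number from compound 3 to compound 4 (0.06 log units; within the scatter). Compound 4 is therefore estimated at 500 nM, with a range of 250 nM to 1000 nM.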

Compound 4, half-maximal inhibitory concentration: 1100 nM
Compound 4: middle estimate off by 2.2-fold (0.34 log units), on the low side; measured number above the stated range.
By their numbers in this assay, from the lowest: compounds 3, 2, 1 and 4 (each within the scatter of the next, the first and the last beyond it).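

In this assay, for the compounds shown here, the swap of isopropoxy to propoxy, which keeps the same atoms joined differently, gives the first step at this position to pass the scatter, a modest one: a 2.5-fold higher number from compound 3 to compound 4 (0.40 log units; beyond the scatter) on an oxygen on an aromatic ring. Going by these compounds alone, the other new steps, a 1.9-fold higher number from compound 2 to compound 4 (0.28 log units; within the scatter) and a 1.5-fold higher number from compound 1 to compound 4 (0.18 log units; within the scatter), both lie within the scatter, so the propyl, pentyl and 3,3,3-trifluoropropyl chains do not separate from one another, and only the pair of compound 3 and compound 4 stands apart, while compound 3 itself remains within the scatter of compound 1 and compound 2. Nothing in hand speaks to the reason for this one step.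

Going by these compounds, the contrast rests on a single branched chain and a single pair, so it remains open whether another branched group, such as a tert-butyl or a cyclopentyl, would stand apart from the propyl chain in the same way. Also open, on these data alone, is how the number responds to a chain ending in an amine or a carboxylic acid on the same oxygen.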